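The source may report more compounds than this note shows. Statements on the series, on what has been measured and on what is new or still open speak of the compounds shown alone.

- compound 1 `COc1ccc([C@@H]2CC(=O)c3cc(CC=C(C)C)c(OC)cc3O2)cc1` - 58%
- compound 2 `COc1cc2c(cc1CC=C(C)C)/C(=N/NC(N)=O)C[C@@H](c1ccc(O)cc1)O2` - 67%

Within the data shown here, in a functional assay on PC-3 cells (Homo sapiens) for inhibition, read by sulforhodamine B assay, with a stated time of 48 h, tested at 50 uM (on this read-out higher numbers stand for more inhibition of growth at the one concentration tested and lower numbers for less inhibition of growth), compound 1 gives 58% and stands within the scatter of compound 2, the only other number available. Compound 3 `COc1cc2c(cc1CC=C(C)C)C(=O)C[C@@H](c1ccc(Oc3ccccc3)cc1)O2` has not been measured yet. It differs from compound 1 at one place (phenyl in place of methyl on an oxygen on an aromatic ring) with phenyl in place of methyl on an oxygen on an aromatic ring. Among the measured compounds shown here, no measured pair shows this change, so no step beyond the scatter is expected. The estimated size of the change is a number 2 percentage points higher from compound 1 to compound 3 (within the scatter) in this reading. For compound 3 the expected value is 60% with an estimated range from 40% to 80% in this assay.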

Compound 3, percent growth inhibition at one concentration: 53%
For compound 3 the middle estimate is 7 percentage points above the measured one; the measured number falls inside the stated range.
By their numbers in this assay, from the lowest: compounds 3, 1 and 2 (each within the scatter of the next, the first and the last beyond it).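

In this assay, phenyl in place of methyl on an oxygen on an aromatic ring, the change of methoxy to phenoxy, gives a number 5 percentage points lower from compound 1 to compound 3 (within the scatter) and so adds one six-membered aromatic ring of carbon only at this position without a step beyond the scatter. This one pair therefore shows that the read-out at the single concentration tolerates phenoxy here. Nothing available bears on the reason for this result.

As far as these compounds go, it remains open how a carboxylic acid or an amine on this aromatic ring would read in this assay, and whether a longer chain on this oxygen would behave as phenyl does.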